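This account rests on a few compounds, and the source may have more. Where it says the series, first, only, none or still open, it means among the compounds named here.

Compound 1 `NC(=O)CCCN(Cc1cccc(C(N)=O)c1)C[C@H]1O[C@@H](n2cnc3c(N)ncnc32)[C@H](O)[C@@H]1O` is the starting point. In an assay on cells for inhibition of Nicotinamide N-methyltransferase (Homo sapiens), with stated times of 10 min and 30 min (a lower number here means a stronger inhibitor, a higher number a weaker inhibitor), compound 1 gives only a limit, > 250000 nM. Compound 2 `NC(=O)CCCCN(Cc1cccc(C(N)=O)c1)C[C@H]1O[C@@H](n2cnc3c(N)ncnc32)[C@H](O)[C@@H]1O` also gives only a limit in this assay, > 250000 nM. Compound 3 `NC(=O)c1cccc(CN(CCCCC(=O)O)C[C@H]2O[C@@H](n3cnc4c(N)ncnc43)[C@H](O)[C@@H]2O)c1` likewise gives only a limit in this assay, > 250000 nM. Because all three values sit at the limit of > 250000 nM in this assay, at which 3 of the 3 values shown sit, the steps a step that the two limits leave unreadable from compound 1 to compound 2, a step that the two limits leave unreadable from compound 1 to compound 3 and a step that the two limits leave unreadable from compound 2 to compound 3 cannot be sized at all. Compound 4 `COC(=O)c1cccc(CN(CCCC(N)=O)C[C@H]2O[C@@H](n3cnc4c(N)ncnc43)[C@H](O)[C@@H]2O)c1` differs from compound 1 by methoxy in place of amino on a carbonyl carbon. Going by the values given here, no measured step shares this change, and none of the measured steps is readable. Compound 4 is therefore expected to stay at or near the limit too, with the step that the limit leaves unreadable from compound 1 to compound 4 estimated as nothing beyond scatter. The estimate for compound 4 in this assay is 300000 nM, between 100000 nM and 1000000 nM.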

Compound 4, half-maximal inhibitory concentration: > 250000 nM
Compound 4 gave a limit, no number; the forecaster's own chance of this, stated with the estimate: 80%; the middle value does not contradict the limit.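

Compound 4 also gives only a limit, > 250000 nM, so the step from compound 1 to compound 4 cannot be read, and nothing can be sized: the limit of > 250000 nM in this assay, at which 4 of the 4 values shown sit.

The compounds shown leave open which change, if any, would give a measurable value in this assay.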